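Hydroxy for methoxy on the chlorophenyl ring

A few compounds are considered here, and "the series" means these few. Any claim that something is new, unique, unknown or untested is made for them only; others in the source may bear on it.

Compound 1 `O=C(Nc1cccc(-n2cc(-c3ccncc3)c(-c3ccc(Cl)c(O)c3)n2)c1)Nc1cccc(C(F)(F)F)c1` gives 3020 nM in a functional assay on RXF 393 cells (Homo sapiens) for inhibition, read by sulforhodamine B assay, with a stated time of 48 h; a lower number here means a stronger inhibitor of growth, a higher number a weaker inhibitor of growth. Compound 2 `O=C(Nc1cccc(-n2cc(-c3ccncc3)c(-c3ccc(Cl)c(O)c3)n2)c1)Nc1ccc(Cl)c(Cl)c1` gives 1000 nM, and compound 3 `COc1cc(-c2nn(-c3cccc(NC(=O)Nc4ccc(Cl)c(C(F)(F)F)c4)c3)cc2-c2ccncc2)ccc1Cl` gives 1180 nM. Compound 3 therefore stands second highest of the three numbers; its gap to compound 2 lies within the scatter, while its gap to compound 1 lies beyond it.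

Among the compounds with values here, the only measured step between compounds that differ in one place, a 3.0-fold lower number from compound 1 to compound 2 (0.48 log units; beyond the scatter), concerns the aryl on the urea nitrogen and leaves the ring carrying the oxygen untouched.

Compound 4 `O=C(Nc1cccc(-n2cc(-c3ccncc3)c(-c3ccc(Cl)c(O)c3)n2)c1)Nc1ccc(Cl)c(C(F)(F)F)c1` differs from compound 3 by hydrogen in place of methyl on an oxygen on an aromatic ring. Within the data shown here, no measured pair isolates this change: compounds 1 and 2 already carry the hydroxy, compound 3 alone carries the methoxy, and all of them differ at the urea aryl as well. What the numbers do show is that compound 2, a hydroxy compound, and compound 3, the methoxy compound, lie within the scatter of each other, even though the urea aryl also differs between them. The expected step from compound 3 to compound 4 is therefore small, a 1.3-fold lower number from compound 3 to compound 4 (0.12 log units; within the scatter), not beyond the scatter. Compound 4 is estimated at 900 nM, with a range from 300 nM to 3000 nM.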

Compound 4, concentration for 50% growth inhibition: 508 nM
The estimate for compound 4 lay 1.8-fold (0.25 log units) above the measured number; the measured number falls inside the stated range.
By their numbers in this assay, from the lowest: compounds 4, 2 and 3 (each within the scatter of the next, the first and the last beyond it); then compound 1.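

In this assay, within the data shown here, compounds 3 and 4 form the first pair that isolates methoxy to hydroxy on the chlorophenyl ring, and a 2.3-fold lower number from compound 3 to compound 4 (0.37 log units; beyond the scatter) puts this single change beyond the scatter, a reading the earlier compounds could not give while the urea aryl also differed. The same compound also sharpens the reading of the urea aryl: chloro in place of hydrogen on an aromatic carbon gives a 5.9-fold lower number from compound 1 to compound 4 (0.77 log units; beyond the scatter), while trifluoromethyl in place of chloro gives a 2.0-fold lower number from compound 2 to compound 4 (0.29 log units; within the scatter) and stays within the scatter. No measurement at hand accounts for any of these steps.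

On these data alone, whether the methoxy to hydroxy step carries over to the 3,4-dichlorophenyl or 3-(trifluoromethyl)phenyl urea stays open, since compounds 1 and 2 appear here only in the hydroxy form. Also open, as far as these compounds go, is how this oxygen would read in this assay when it carries an ethyl group, a longer chain or a chain ending in an amine. Methyl and hydrogen are the only two substituents shown there.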